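A few compounds are considered here, and "the series" means these few. Any claim that something is new, unique, unknown or untested is made for them only; others in the source may bear on it.

Measured so far in an assay on HL-60 cells for agonist activity at vitamin D3 receptor (Homo sapiens), read by microscopy, with a stated time of 96 h; a lower number here means that less compound is needed, a higher number that more compound is needed for the effect:
compound 1, `CCOC(=O)CN(C)C(=O)c1ccc(C(CC)(CC)c2ccc(OCC(O)C(C)(C)C)c(C)c2)n1CC`, gives 210 nM;
compound 2, `CCN(CC)CCNC(=O)c1ccc(C(CC)(CC)c2ccc(OCC(O)C(C)(C)C)c(C)c2)n1CC`, gives 110 nM.

Among the measured compounds shown here, on these two numbers compound 2 holds the lower one, and its only neighbour is compound 1; the step of a 1.9-fold lower number from compound 1 to compound 2 (0.28 log units; within the scatter) lies within the scatter. Compound 3, `CCn1c(C(=O)NCCCN(C)C)ccc1C(CC)(CC)c1ccc(OCC(O)C(C)(C)C)c(C)c1`, differs from compound 2 by (dimethylamino)methyl in place of diethylamino on a saturated chain carbon, two bonds along the chain from an amide-type nitrogen. For the measured compounds named here, no measured step bears directly on this change, since the single measured step, a 1.9-fold lower number from compound 1 to compound 2 (0.28 log units; within the scatter), concerns a different part of the molecule and is itself within the scatter. The step of no change at the digits printed from compound 2 to compound 3 (within the scatter) is therefore expected to stay within the scatter. Compound 3 is expected to give 110 nM, in the range 50 nM to 250 nM.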

Compound 3, half-maximal effective concentration: 37 nM
Compound 3: middle estimate off by 3.0-fold (0.47 log units), on the high side; measured number outside the range, below it.
By their numbers in this assay, from the lowest: compound 3; then compounds 2 and 1 (each within the scatter of the next).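

In this assay, among the compounds shown here, (dimethylamino)methyl in place of diethylamino on a saturated chain carbon, two bonds along the chain from an amide-type nitrogen, gives a 3.0-fold lower number from compound 2 to compound 3 (0.47 log units; beyond the scatter) and so is the first change here to exceed the scatter. Replacing ((ethoxycarbonyl)methyl)(methyl)amino with (3-(dimethylamino)propyl)amino on the carbonyl carbon gives a 5.7-fold lower number from compound 1 to compound 3 (0.75 log units; beyond the scatter) as well. No evidence is available to explain either step.

The compounds shown do not separate the longer chain from the smaller amine end. A 3-(diethylamino)propyl or 2-(dimethylamino)ethyl chain would pull these two apart.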